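The source may report more compounds than this note shows. Statements on the series, on what has been measured and on what is new or still open speak of the compounds shown alone.

Three compounds were measured in a functional assay, read by fluorescence and spectrophotometry, with a stated time of 1 h; on this read-out lower numbers stand for an effect already at smaller amounts and higher numbers for an effect only at larger amounts of compound:

compound 1 `O=S(=O)(/C=C/c1ccc(O)c(O)c1)CCC1CCCCC1` gives 9800 nM
compound 2 `O=S(=O)(/C=C/c1ccc(O)c(O)c1)CCCCCCCCCO` gives 7500 nM
compound 3 `CCCCCCCCS(=O)(=O)/C=C/c1ccc(O)c(O)c1` gives 6400 nM

Compound 1 stands at the highest of the three numbers. Nearest to it is compound 2 with 7500 nM, and furthest from it is compound 3 with 6400 nM; the step of a 1.5-fold lower number from compound 1 to compound 3 (0.19 log units; within the scatter) and the step of a 1.2-fold lower number from compound 2 to compound 3 (0.07 log units; within the scatter) both lie within the scatter, so the three compounds cannot be ordered against one another.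

Compound 4 `O=S(=O)(/C=C/c1ccc(O)c(O)c1)CC1CCCC1` is not yet measured. It differs from compound 1 in one place: cyclopentyl in place of cyclohexylmethyl on a saturated chain carbon bound to a sulfonyl sulfur. The step that bears on this change is a 1.5-fold lower number from compound 1 to compound 3 (0.19 log units; within the scatter), where the cyclohexyl was exchanged at a saturated chain carbon near the sulfonyl sulfur and the number barely moved; a 1.2-fold lower number from compound 2 to compound 3 (0.07 log units; within the scatter), a change at the far end of the chain, was also within the scatter. Every change so far on the chain beyond the sulfonyl group has left the read-out within the scatter, and nothing in the three compounds suggests the move to cyclopentyl will behave otherwise, so no step beyond the scatter is expected from compound 1 to compound 4 in this assay, an expected step of a 1.1-fold lower number from compound 1 to compound 4 (0.04 log units; within the scatter). Compound 4 is therefore expected to give about 9000 nM, with a range from 4000 nM to 20000 nM.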

Compound 4, half-maximal effective concentration: 9400 nM
Compound 4: the middle estimate sits 1.0-fold (0.02 log units) below what was measured, within the range that was stated.
By their numbers in this assay, from the lowest: compounds 3, 2, 4 and 1 (each within the scatter of the next).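

In this assay, the ring itself can differ at this place without the number leaving the scatter: cyclopentyl in place of cyclohexylmethyl on a saturated chain carbon bound to a sulfonyl sulfur gives a 1.0-fold lower number from compound 1 to compound 4 (0.02 log units; within the scatter). For the compounds shown here, the earlier compounds had varied only a cyclohexyl against an open chain or the far end of a chain, so this is the first step to exchange one ring of carbon for a different, five-membered one. An open chain and this five-membered ring also stay within the scatter of each other, with a 1.5-fold higher number from compound 3 to compound 4 (0.17 log units; within the scatter), so this assay does not tell cyclopentyl from heptyl here.

Nothing available explains why these steps stay so small. Going by these compounds, whether an amine or a carboxylic acid at this place would carry the number beyond the scatter remains open.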